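The compounds below may be only part of what the source reports. "The series", "measured", "known", "first", "only" and "open" are said of these compounds alone.

Compound 1, `CCOc1cccc(-c2ccc(CN(C(=O)C3CCCCC3)c3cccc(/C=C/C(=O)OC)c3)cc2)c1`: 147 nM
Compound 2, `CCOc1cccc(-c2ccc(CN(C(=O)C(C)C)c3cccc(/C=C/C(=O)OC)c3)cc2)c1`: 173 nM
Compound 3, `COC(=O)/C=C/c1cccc(N(Cc2ccc(/C=C/C(=O)OC(C)(C)C)cc2)C(=O)c2ccccc2)c1`: 236 nM

All three compounds were tested in an assay on isolated protein with Bile acid receptor (Homo sapiens) as the target; a higher number here means that more compound is needed for the effect, a lower number that less compound is needed. Compound 2 sits between the other two on these numbers, but its nearest neighbour compound 1 lies only a 1.2-fold higher number from compound 1 to compound 2 (0.07 log units; within the scatter) away, and compound 3 is also within the scatter of compound 2, so the three compounds cannot be told apart by this assay.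

The step to compound 4, `COC(=O)/C=C/c1cccc(N(Cc2ccc(/C=C/c3ccccc3)cc2)C(=O)C(C)C)c1`, changes a different part of the molecule: 2-phenylethenyl in place of 3-ethoxyphenyl on an aromatic carbon. Within the data shown here, the only measured step, from compound 1 to compound 2, swaps a group on a carbonyl carbon and stays within the scatter; it does not touch the aromatic carbon that changes here. Among the measured compounds shown here, no measured pair replaces the 3-ethoxyphenyl, so nothing in the data shows how this assay responds to the new 2-phenylethenyl group.

For the measured compounds named here, with no step to lean on, the expectation for compound 4 is a number close to compound 2, with a wide range on both sides. Compound 4 is estimated at 220 nM, between 90 nM and 550 nM. This estimate means a step of a 1.3-fold higher number from compound 2 to compound 4 (0.10 log units; within the scatter), which is expected to stay within the scatter.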

Compound 4, half-maximal effective concentration: 65 nM
Compound 4: middle estimate off by 3.4-fold (0.53 log units), on the high side, and the stated range ends above it.
By their numbers in this assay, from the lowest: compound 4; then compounds 1, 2 and 3 (each within the scatter of the next).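

In this assay, among these compounds, the aromatic carbon that carries the 3-ethoxyphenyl group responds to what sits on it: putting 2-phenylethenyl there gives a 2.7-fold lower number from compound 2 to compound 4 (0.43 log units; beyond the scatter) and is the first step in this set beyond the scatter. The earlier swap on the carbonyl carbon, a 1.2-fold higher number from compound 1 to compound 2 (0.07 log units; within the scatter), stayed within it, so the two places in the molecule do not behave alike in the steps seen so far. The leaving group holds 1 hydrogen-bond acceptor and the entering group 0, the entering group adds 1 double bond outside aromatic rings, and no evidence at hand says which of these differences, if either, accounts for the lower number.

Whether the double bond itself matters stays open, since the compounds shown include neither 2-phenylethyl, the same group with that double bond saturated, nor a plain phenyl group on this carbon. Also open, on these data alone, are whether the same swap gives a similar step with cyclohexyl on the carbonyl carbon, and how an amine or a carboxylic acid on this aromatic carbon would read in this assay.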